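Swapping a pyridine for a thiophene on a shared pyridine core

The source may hold more compounds than are shown below. What is called first, only, known or untested is meant among the compounds shown, and "the series" means these compounds.

Of the compounds shown here, two with a common core have been measured in an assay on isolated protein for inhibition of DNA topoisomerase 1 (Homo sapiens), with a stated time of 30 min, tested at 100 uM; a lower number here means a weaker effect, a higher number a stronger effect of the compound at the concentration tested. Compound 1 `Oc1cccc(-c2cc(-c3ccc(Cl)cc3)nc(-c3cccs3)c2)c1` gives 15.1% in this assay. Compound 2 `Oc1cccc(-c2cc(-c3cccnc3)nc(-c3ccccc3Cl)c2)c1` gives 0% in this assay, the lowest of the two numbers; compound 1 stands above it by a margin beyond the usual scatter. Going by the values given here, no pair among the measured compounds differs in only one place, so no single structural step can be read from them directly.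

Compound 3 `Oc1cccc(-c2cc(-c3cccs3)nc(-c3ccccc3Cl)c2)c1` is not yet measured. It differs from compound 2 in one place: thiophen-2-yl in place of pyridin-3-yl on an aromatic carbon. Compound 1 also carries a thiophen-2-yl group on its core, while its chlorophenyl group is a 4-chlorophenyl rather than the 2-chlorophenyl of compound 2 and compound 3, so compound 1 is only a loose guide.

The step of a number 7 percentage points higher from compound 2 to compound 3 (within the scatter) is expected to be small and upward, within or just at the edge of the scatter. In this assay compound 3 is estimated at 7%, with a range from 0% to 20%.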

Compound 3, a percentage reported as inhibition, at one concentration (the size of the read-out at that concentration, not a potency): 2.7%
Compound 3: the middle estimate sits 4.3 percentage points above what was measured; the measured number falls inside the stated range.
By their numbers in this assay, from the lowest: compounds 2 and 3 (each within the scatter of the next); then compound 1.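

In this assay, the change at this position, next to the ring nitrogen, gives a number 2.7 percentage points higher from compound 2 to compound 3 (within the scatter). With a 2-chlorophenyl group on the shared core, thiophen-2-yl in place of pyridin-3-yl therefore leaves the read-out within the usual scatter, and both compounds sit close to the bottom of what this assay can show. Compound 3 also gives the first comparison with compound 1 that rests on a single change, since 2-chlorophenyl in place of 4-chlorophenyl with the thiophen-2-yl group kept gives a number 12.4 percentage points lower from compound 1 to compound 3 (beyond the scatter), a modest step beyond the scatter, and it is the chlorophenyl change rather than the heteroaromatic ring swap that moves the number among these compounds. No measurement at hand accounts for the size of either step.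

From the compounds shown here alone, it remains open whether pyridin-3-yl and thiophen-2-yl would also match when a 4-chlorophenyl group sits on the core, where the read-out has room to fall. Going by these compounds, it is equally open whether a piperazine or a carboxylic acid at this position, or a 3-chlorophenyl group in place of the 2-chlorophenyl group, would shift the number in this assay beyond the scatter.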